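The source may report more compounds than this note shows. Statements on the series, on what has been measured and on what is new or still open speak of the compounds shown alone.

Three compounds have been measured in an ADME assay on Vero cells (Chlorocebus sabaeus) for cytotoxicity, read by MTT assay, with a stated time of 72 h; on this read-out higher numbers stand for weaker inhibition and lower numbers for stronger inhibition:

Compound 1, `COc1ccc2c(c1)[n+]([O-])c(C#N)c(-c1ccc(F)cc1)[n+]2[O-]`, gives 95.1 ug/mL.
Compound 2, `COc1ccc2c(c1)[n+]([O-])c(C#N)c(-c1ccc(Cl)cc1)[n+]2[O-]`, gives 1 ug/mL.
Compound 3, `COC(=O)c1ccc(-c2c(C#N)[n+]([O-])c3cc(F)ccc3[n+]2[O-])cc1`, gives 57.5 ug/mL.

Compound 1 and compound 2 share one core and differ only in the group that sits on the pendant ring: chloro in place of fluoro on an aromatic carbon. That single exchange gave a 95-fold lower number from compound 1 to compound 2 (1.98 log units; beyond the scatter), a step that stands well beyond the usual scatter of this assay.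

Compound 3 carries a different core, and the difference between the two cores is not broken down here. Its number lies within the scatter of that of compound 1, so nothing separates them, while the number of compound 2 lies far below both.

Compound 4, `COC(=O)c1ccc(-c2c(C#N)[n+]([O-])c3cc(Cl)ccc3[n+]2[O-])cc1`, has not yet been measured. It relates to compound 3 as compound 2 does to compound 1: chloro in place of fluoro on an aromatic carbon. The change is of the same kind, but not the same, since it now falls on an aromatic carbon of a six-membered aromatic ring of carbon only, part of a fused or bridged system of two rings, meta to a fused ring and para to a fused ring, whereas in compound 2 it sat on a ring para to a large group. For the measured compounds named here, because the earlier exchange gave a 95-fold lower number from compound 1 to compound 2 (1.98 log units; beyond the scatter), a lower number is expected for compound 4 in this assay, though with a smaller step, since only one such exchange, at a different place, is known here. The expected step is a 5.8-fold lower number from compound 3 to compound 4 (0.76 log units; beyond the scatter). Compound 4 is estimated at 10 ug/mL, between 1.5 ug/mL and 50 ug/mL.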

Compound 4, half-maximal inhibitory concentration: 20.9 ug/mL
Compound 4: the middle estimate sits 2.1-fold (0.32 log units) below what was measured; low and high end bracket the measured number.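

In this assay, chloro in place of fluoro on an aromatic carbon gave a 2.8-fold lower number from compound 3 to compound 4 (0.44 log units; beyond the scatter), so the number moved in the same direction on both cores, and in both pairs the chloro compound has the lower number. The direction of the change therefore carried over in these two pairs, but its size did not: the same change on two cores in this assay, a 95-fold lower number (1.98 log units; beyond the scatter) from compound 1 to compound 2 and a 2.8-fold lower number (0.44 log units; beyond the scatter) from compound 3 to compound 4, 35-fold (1.54 log units) apart, beyond the scatter of two such steps This does not show what sets the size of the step, since the two pairs differ both in the rest of the molecule and in where the exchange falls: on the pendant ring from compound 1 to compound 2, and on a ring that is part of a fused or bridged system of two rings from compound 3 to compound 4. For the compounds shown here, with only two pairs, neither difference can be singled out, and no general size can be stated for this exchange across the series.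

The compounds shown leave open how a bromo group on the same aromatic carbon would compare with chloro and fluoro on either core. They also leave open how the number would respond to a carboxylic acid or an amide in place of the ester on the pendant ring of compound 4.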